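The compounds below may be only part of what the source reports. "The series", "measured", "known", "first", "only" and "open" are said of these compounds alone.

Among the measured compounds shown here, in an assay on isolated protein for displacement of a labelled ligand from metabotropic glutamate receptor 5 (Homo sapiens), with a stated time of 60 min, tested at 1 uM (a higher number here means more inhibition at the concentration tested (going by the name of the read-out), a lower number less inhibition), three compounds have numbers so far. Compound 2 `COc1cccc(S(=O)(=O)c2cnc3ccc(F)cc3c2N2CCC(C)CC2)c1` gives 90%, compound 3 `CC1CCN(c2c(S(=O)(=O)c3ccc(F)c(F)c3)cnc3ccc(F)cc23)CC1` gives 82%, and compound 1 `Cc1ccc2ncc(S(=O)(=O)c3ccc(C#N)cc3)c(N3CCC(C)CC3)c2c1` gives 55%. Compound 3 thus stands second highest of the three: the step of a number 8 percentage points lower from compound 2 to compound 3 (within the scatter) lies within the scatter, while compound 1 sits beneath compound 3 by a margin beyond the scatter. Compound 4 `CC1CCN(c2c(S(=O)(=O)c3ccc(C#N)cc3)cnc3ccc(F)cc23)CC1` has not yet been measured. It differs from compound 3 in one place: 4-cyanophenyl in place of 3,4-difluorophenyl on a sulfonyl sulfur. For the measured compounds named here, only one measured step changes the group on the sulfonyl sulfur, and it moved this assay by a number 8 percentage points lower from compound 2 to compound 3 (within the scatter), within the scatter; it does not involve the entering group, so it shows only that such swaps can be small. Going by the values given here, compound 1 is the one measured compound that carries a 4-cyanophenyl on a sulfonyl sulfur, and it gives the lowest of the three numbers. Weighing these, a modest fall is expected, a number 17 percentage points lower from compound 3 to compound 4 (beyond the scatter). Compound 4 is therefore estimated at 65%, within a range from 45% to 82%.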

Compound 4, a percentage reported as inhibition, at one concentration (the size of the read-out at that concentration, not a potency): 75%
The estimate for compound 4 lay 10 percentage points below the measured number; low and high end bracket the measured number.
By their numbers in this assay, from the lowest: compound 1; then compounds 4, 3 and 2 (each within the scatter of the next, the first and the last beyond it).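

In this assay, 4-cyanophenyl on a sulfonyl sulfur can be carried on a fluoro-bearing core with little loss: replacing 3,4-difluorophenyl gives a number 7 percentage points lower from compound 3 to compound 4 (within the scatter) and no clear separation, while replacing 3-methoxyphenyl gives a number 15 percentage points lower from compound 2 to compound 4 (beyond the scatter) and a real drop. With 4-cyanophenyl held constant, fluoro in place of methyl on an aromatic carbon gives a number 20 percentage points higher from compound 1 to compound 4 (beyond the scatter) and so the low number of compound 1 cannot be laid on 4-cyanophenyl alone. Nothing measured here explains these shifts.

Among the compounds shown here, compound 1 is the only compound with methyl at that carbon, so it remains open whether fluoro would give a similar rise with other groups on the sulfonyl sulfur. Also open, going by these compounds, is how a plain ethyl chain or a phenyl carrying an amine would fare on that sulfur.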